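This account rests on a few compounds, and the source may have more. Where it says the series, first, only, none or still open, it means among the compounds named here.

Series notes. Compound 1 `NS(=O)(=O)Cc1noc2ccc(F)cc12` gives 15 mg/kg in a functional assay on the whole organism (strain STD-dd) with Mus musculus as the target, in the maximal electroshock model, with a stated time of 2 h; on this read-out lower numbers stand for an effect already at smaller amounts and higher numbers for an effect only at larger amounts of compound. Compound 2 `CNS(=O)(=O)Cc1noc2ccc(F)cc12` gives 35 mg/kg in this assay, and compound 3 `CCNS(=O)(=O)Cc1noc2ccc(F)cc12` gives 32 mg/kg. The step of a 2.3-fold higher number from compound 1 to compound 2 (0.37 log units; beyond the scatter) and the step of a 2.1-fold higher number from compound 1 to compound 3 (0.33 log units; beyond the scatter) both run modestly the same way, while the step of a 1.1-fold lower number from compound 2 to compound 3 (0.04 log units; within the scatter) stays within the scatter. On these numbers compound 3 stands second highest, nearest compound 2 and furthest from compound 1. Going by these compounds, compound 4 `CC(C)NS(=O)(=O)Cc1noc2ccc(F)cc12` is untested; its change from compound 3 is methyl in place of hydrogen on a saturated chain carbon bound to a saturated chain carbon and a sulfonamide nitrogen. For the measured compounds named here, the closest precedent is the flat step a 1.1-fold lower number from compound 2 to compound 3 (0.04 log units; within the scatter), so no movement beyond the scatter is expected in this assay. For compound 4 the expected step is a 1.3-fold higher number from compound 3 to compound 4 (0.10 log units; within the scatter). Compound 4 is estimated at 40 mg/kg, within 20 mg/kg to 80 mg/kg.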

Compound 4, dose for half-maximal effect: 38 mg/kg
The estimate for compound 4 lay 1.1-fold (0.02 log units) above the measured number; the range from low to high includes it.
By their numbers in this assay, from the lowest: compound 1; then compounds 3, 2 and 4 (each within the scatter of the next).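

Replacing hydrogen with methyl on the saturated chain carbon bound to a saturated chain carbon and a sulfonamide nitrogen, which turns ethyl into isopropyl, gives no movement beyond the scatter (a 1.2-fold higher number from compound 3 to compound 4 (0.07 log units; within the scatter)). Isopropyl in place of methyl on the sulfonamide nitrogen also stays within it (a 1.1-fold higher number from compound 2 to compound 4 (0.04 log units; within the scatter)), so this branched group cannot be told apart from the two smaller ones, while isopropyl in place of hydrogen gives a modest shift (a 2.5-fold higher number from compound 1 to compound 4 (0.40 log units; beyond the scatter)). No measured data explain this pattern. Going by these compounds, a longer chain such as n-butyl, or a carboxylic acid or an amine carried on the nitrogen substituent, remains open.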